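Swapping the Ring on the Side Chain of Compound 2

This account rests on a few compounds, and the source may have more. Where it says the series, first, only, none or still open, it means among the compounds named here.

In a physicochemical assay for solubility, measured as kinetic solubility (on this read-out higher numbers stand for higher solubility and lower numbers for lower solubility), compound 1 `CNc1nccc(N2CC[C@H](NC(=O)Nc3ccc(Cl)c(C(F)(F)F)c3)C2)n1` gives 22200 nM, compound 2 `CNc1nccc(N2CC[C@H](NC(=O)Nc3ccc(CN4CCC4)c(C(F)(F)F)c3)C2)n1` gives 84900 nM and compound 3 `CNc1nccc(N2CC[C@H](NC(=O)Nc3cccc(OC)c3)C2)n1` gives 116000 nM. Compound 2 is therefore level with compound 3 within the scatter, and stands beyond the scatter above compound 1.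

Compound 4 `CNc1nccc(N2CC[C@H](NC(=O)Nc3ccc(CN4CCN(C)CC4)c(C(F)(F)F)c3)C2)n1` places 4-methylpiperazin-1-yl in place of azetidin-1-yl on a saturated chain carbon bound to an aromatic carbon. Among the compounds with values here, the one measured step that bears on this is the modest 3.8-fold higher number from compound 1 to compound 2 (0.58 log units; beyond the scatter), where (azetidin-1-yl)methyl replaced chloro. Within the data shown here, no measured step tests this ring swap directly, so no change beyond the scatter is expected in this assay. The estimated change is a 1.1-fold higher number from compound 2 to compound 4 (0.03 log units; within the scatter). For compound 4 the expected value is 90000 nM, within a range of 40000 nM to 180000 nM.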

Compound 4, solubility: 67500 nM
Beside the measured number, compound 4's estimate is 1.3-fold (0.12 log units) above it, within the range that was stated.
By their numbers in this assay, from the lowest: compound 1; then compounds 4, 2 and 3 (each within the scatter of the next).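

Exchanging azetidin-1-yl for 4-methylpiperazin-1-yl on this saturated chain carbon, a swap to a six-membered ring with two nitrogens, makes no change beyond the scatter in this assay (a 1.3-fold lower number from compound 2 to compound 4 (0.10 log units; within the scatter)). The step away from chloro also remains beyond the scatter with the new ring (a 3.0-fold higher number from compound 1 to compound 4 (0.48 log units; beyond the scatter)), so both ring-bearing side chains stand clear of compound 1. No available evidence explains either step.

A morpholin-4-yl ring or an open-chain dimethylamino group on the same carbon would show whether this level extends beyond these two rings.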